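The source may report more compounds than this note shows. Statements on the series, on what has been measured and on what is new or still open speak of the compounds shown alone.

Measured compounds:
compound 1 `O=C(Nc1nc2ccc(Cl)cc2s1)c1cn(-c2ccccc2)nc1-c1ccc(Cl)cc1` — 4550 nM
compound 2 `COc1ccc(-c2nn(-c3ccccc3)cc2C(=O)Nc2nc3ccccc3s2)cc1` — 10500 nM

In a functional assay on HT-29 cells (Homo sapiens) for cytotoxicity, read by MTT assay, with a stated time of 72 h (on this read-out lower numbers stand for stronger inhibition and higher numbers for weaker inhibition), compound 2 gives 10500 nM, the highest of the two numbers shown. Compound 1 gives 4550 nM in this assay, a lower number and beyond the scatter. Going by the values given here, the two compounds differ in two places at once, so no single step between them can be read.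

Compound 3 `COc1ccc(-c2nn(-c3ccccc3)cc2C(=O)Nc2nc3ccc(Cl)cc3s2)cc1` is compound 2 with chloro in place of hydrogen on an aromatic carbon. Among the compounds with values here, no measured pair isolates this change. Compound 1 also carries the 6-chloro-1,3-benzothiazol-2-yl group and shows the lower number of the two, but its other aryl group differs as well, so that comparison is not clean. Expected is a small step toward a lower number, possibly still within the scatter: a 1.6-fold lower number from compound 2 to compound 3 (0.21 log units; within the scatter). Compound 3 is expected at 6500 nM in this assay, in the range 2500 nM to 16000 nM.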

Compound 3, half-maximal inhibitory concentration: 6570 nM
Beside the measured number, compound 3's estimate is 1.0-fold (0.00 log units) below it, and the stated range covers the measured number.
By their numbers in this assay, from the lowest: compounds 1, 3 and 2 (each within the scatter of the next, the first and the last beyond it).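

In this assay, chloro in place of hydrogen on the aromatic carbon of the benzothiazole, which turns 1,3-benzothiazol-2-yl into 6-chloro-1,3-benzothiazol-2-yl, can now be read alone and gives a 1.6-fold lower number from compound 2 to compound 3 (0.20 log units; within the scatter) and so does not separate from repeat measurement. Methoxy in place of chloro on an aromatic carbon of the other aryl group can also be read alone and gives a 1.4-fold higher number from compound 1 to compound 3 (0.16 log units; within the scatter) and thus is likewise unresolved, so neither single change on its own yields a step beyond the scatter. Nothing measured on these compounds offers an explanation for either step.

Open, on these data alone, is whether an amine or a carboxylic acid on the same aromatic carbon would give a step beyond the scatter. Also open, as far as these compounds go, is whether these small steps hold in other cell lines.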